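The source may hold more compounds than are shown below. What is called first, only, known or untested is meant among the compounds shown, and "the series" means these compounds.

Of the compounds shown here, three on a shared core have been read in an ADME assay on BJ cells (Homo sapiens) for cytotoxicity, with a stated time of 72 h; on this read-out higher numbers stand for an effect only at larger amounts of compound and lower numbers for an effect already at smaller amounts. Compound 1 `C=C[C@@](C)(/C=C/c1ccc(OC)cc1)CCC=C(C)C` gives > 36600 nM, which is a limit of the assay and not a number. Compound 2 `C=C[C@@](C)(/C=C/c1ccc(O)c(/C=C/C#N)c1)CCC=C(C)C` gives > 36600 nM, again a limit. Compound 3 `C=C[C@@](C)(/C=C/c1ccc(O)c(/C=C/C(=O)OCc2ccccc2)c1)CCC=C(C)C` gives > 36600 nM, also a limit. Compound 3 therefore stands at the limit of > 36600 nM in this assay, at which 3 of the 3 values shown sit, and no number places it relative to the other two.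

The next compound is compound 4 `C=C[C@@](C)(/C=C/c1ccc(O)c(/C=C/c2ccc(Cl)c(Cl)c2)c1)CCC=C(C)C`, which carries 3,4-dichlorophenyl in place of benzyloxycarbonyl on a double-bonded chain carbon bound to a double-bonded chain carbon. Among the compounds with values here, the one measured step at this place is a step that the two limits leave unreadable from compound 2 to compound 3. That step swapped a different group on the same chain, but it offers no size to carry forward, so the expectation rests only on the shared limit of compound 1, compound 2 and compound 3. No clear move in either direction is expected in this assay, although a modest shift toward smaller amounts cannot be excluded. The expected outcome is a number no higher from compound 3 to compound 4 (the limit leaves the size open). The estimated value for compound 4 is 36600 nM, expected to fall in the range from 12000 nM to 80000 nM. A further report of only a limit is the likeliest result.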

Compound 4, half-maximal effective concentration: > 13000 nM
Compound 4: a limit, no number; the forecaster's own chance of this, stated with the estimate: 70%; the middle value does not contradict the limit.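

In this assay compound 4 gives > 13000 nM, which is a limit of the assay and not a number. The steps to compound 4 from compound 2 and compound 3 therefore cannot be read. The compounds shown leave open at what amount, if any, compound 1, compound 2, compound 3 or compound 4 would show an effect in this assay.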